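From Dimethylphenyl to Difluorophenyl on the Amide Nitrogen

This account rests on a few compounds, and the source may have more. Where it says the series, first, only, none or still open, it means among the compounds named here.

Measured compounds:
compound 1, `CCN1CCc2c(c(C)nn2C(=O)Nc2c(C)cccc2C)C1`: 12.2%
compound 2, `CCN1CCc2c(c(C)nn2C(=O)Nc2ccc(C)cc2C)C1`: 7%
compound 3, `CCN1CCc2c(c(C(C)(C)C)nn2C(=O)Nc2c(C)cccc2C)C1`: 15.7%

Among the measured compounds shown here, in a functional assay on the whole organism (strain Swiss albino) for inhibition, with Mus musculus as the target, in the formalin test, with stated times of 30 min and 5 min, at a dose of 100 mg/kg (on this read-out higher numbers stand for more inhibition at the one dose given (going by the name of the read-out) and lower numbers for less inhibition), compound 3 gives 15.7%, the highest of the three numbers, but this rank is thin: the only one-point step among them, a number 3.5 percentage points higher from compound 1 to compound 3 (within the scatter), does not leave the scatter, and compound 2 with 7% lies within the scatter of compound 3 as well. Compound 1 and compound 2 share the same substituent pattern on the shared core and differ only in where the two methyl groups sit on the phenyl ring; their two values show nothing beyond the scatter.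

Compound 4, `CCN1CCc2c(c(C(C)(C)C)nn2C(=O)Nc2ccc(F)cc2F)C1`, is the next step from compound 3: 2,4-difluorophenyl in place of 2,6-dimethylphenyl on an amide-type nitrogen. For the measured compounds named here, no measured pair bears on this change. Going by the values given here, the one measured step, a number 3.5 percentage points higher from compound 1 to compound 3 (within the scatter), concerns a different position and was within the scatter, so it gives no guide to the aryl swap. With nothing in the data pointing either way, the expectation for this assay is a step of about a number 1.7 percentage points lower from compound 3 to compound 4 (within the scatter), that is, none beyond the scatter. Compound 4 is therefore estimated at 14%, within a range from 3% to 27%.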

Compound 4, a percentage reported as inhibition, in the whole organism at one dose (the size of the read-out at that dose, not a potency): 4.4%
Beside the measured number, compound 4's estimate is 9.6 percentage points above it; the measured number falls inside the stated range.
By their numbers in this assay, from the lowest: compounds 4, 2, 1 and 3 (each within the scatter of the next, the first and the last beyond it).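

In this assay, the aryl group on the amide-type nitrogen is where a single change first carries the number beyond the scatter: 2,4-difluorophenyl in place of 2,6-dimethylphenyl gives a number 11.3 percentage points lower from compound 3 to compound 4 (beyond the scatter). The earlier step at the aromatic carbon, a number 3.5 percentage points higher from compound 1 to compound 3 (within the scatter), stayed within the scatter, so only now does the read-out show that it can respond to a one-place change in these compounds, and that the group on this nitrogen is such a place. Nothing at hand says why the number falls with this swap.

The compounds shown leave open whether the fall goes with the fluorine atoms or with their arrangement on the ring, for 2,6-dimethylphenyl and 2,4-difluorophenyl differ in both, and a 2,6-difluorophenyl or a plain phenyl group on the same nitrogen would separate the two. Also open, as far as these compounds go, is whether the same swap gives a similar step with methyl in place of tert-butyl on the aromatic carbon, and how a benzyl group or a pyridyl ring on the amide-type nitrogen would read in this assay.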